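Swapping the aryl group on the ring amine of compound 1

The compounds below may be only part of what the source reports. "The series", "measured", "known", "first", "only" and "open" are said of these compounds alone.

compound 1, `CCCc1nc(-c2ccccc2)c(CNCCN2CCN(c3ccccc3OC)CC2)o1`: 39.7%
compound 2, `Cc1nc(-c2ccccc2)c(CNCCCN2CCN(c3ccc(Cl)cc3)CC2)o1`: 38.1%
compound 3, `CCCc1nc(-c2ccccc2)c(CNCCCN2CCN(c3ccc(C(F)(F)F)cc3)CC2)o1`: 51.6%

Of the compounds shown here, three have so far been measured in an assay on HEK293 cells for inhibition of Voltage-dependent T-type calcium channel subunit alpha-1G (Homo sapiens), read by fluorescence, tested at 10 uM; a higher number here means more inhibition at the concentration tested (going by the name of the read-out), a lower number less inhibition. Compound 1 gives 39.7%, the second highest of the three numbers. Its nearest neighbour is compound 2, which gives 38.1%; that number is lower by an amount that lies within the scatter of repeated measurements, so the two cannot be told apart. The furthest is compound 3, which gives 51.6%, higher than compound 1 by an amount beyond the scatter. Compounds 2 and 3 each differ from compound 1 in more than one place, so no single structural change can be read off from these three.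

Compound 4, `CCCc1nc(-c2ccccc2)c(CNCCN2CCN(c3cccc(C)c3C)CC2)o1`, has not yet been measured. It differs from compound 1 in one place: 2,3-dimethylphenyl in place of 2-methoxyphenyl on an amine nitrogen in a ring. Within the data shown here, no measured pair shows this change, so its effect in this assay is unknown. The expected step for a number 2.3 percentage points higher from compound 1 to compound 4 (within the scatter) is therefore small, with no clear direction, and not beyond the scatter. For compound 4 the estimate in this assay is 42%, with a range from 25% to 60%.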

Compound 4, a percentage reported as inhibition, at one concentration (the size of the read-out at that concentration, not a potency): 66.7%
The estimate for compound 4 lay 24.7 percentage points below the measured number; the whole stated range lies below it.
By their numbers in this assay, from the lowest: compounds 2 and 1 (each within the scatter of the next); then compound 3; then compound 4.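

Among these compounds, this is the first change that can be read at a single place. In this assay, putting 2,3-dimethylphenyl in place of 2-methoxyphenyl on the amine nitrogen in the ring gives a number 27 percentage points higher from compound 1 to compound 4 (beyond the scatter), so the read-out responds to the aryl group at this position while the rest of the structure stays fixed. The two groups have the same number of heavy atoms and the same six-membered aromatic ring of carbon only, and they differ in that 2-methoxyphenyl has an oxygen and a hydrogen-bond acceptor and 2,3-dimethylphenyl has neither. Nothing measured here explains the step.

As far as these compounds go, it remains open whether one methyl group, as in 2-methylphenyl or 3-methylphenyl, would account for the step, or whether both are needed, and whether a halogen such as chlorine in the same place, as in 2-chlorophenyl, would act alike. Also open, from the compounds shown here alone, is whether this aryl change would give a similar step on a compound with a longer chain between the two amine nitrogens.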